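The compounds below may be only part of what the source reports. "The series", "measured", "known", "first", "only" and "open" are said of these compounds alone.

The study centres on a shared core carrying a fused benzothiazole ring. For compound 1 `Cc1cncc(Cl)c1N1CCN(C(=O)CCS(=O)(=O)c2cccc3ncsc23)CC1` the result in an ADME assay on microsomes from liver (Rattus norvegicus) for metabolic stability, read by LC-MS, with a stated time of 15 min, tested at 1 uM (on this read-out higher numbers stand for a more stable compound and lower numbers for a less stable compound), is "not determined" (no result reported). Compound 2 `Cc1cc(F)cnc1N1CCN(C(=O)CCCc2cccc3ncsc23)[C@@H](C)C1` gives 5.3% in this assay, and compound 3 `O=C(CCS(=O)(=O)c1cccc2ncsc12)N1CCN(c2ccc(C(F)(F)F)cn2)CC1` gives 41%. Among the two reported numbers, compound 2 stands lowest, with compound 3 lying higher by a margin beyond the usual scatter; compound 1 contributes no number for comparison.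

Compound 4 `Cc1cc(F)cnc1N1CCN(C(=O)CCCc2cccc3nc(N)sc23)[C@@H](C)C1` follows from compound 2 by a single change (amino in place of hydrogen on an aromatic carbon). Among the measured compounds, no pair differs by exactly this change, so the data give no direct precedent for its size or direction. Among the measured compounds shown here, because compound 2 sits at 5.3%, there is little room for a downward move, and with no comparable step recorded, the expectation is a modest upward shift at most, possibly none beyond the scatter. The estimated step from compound 2 to compound 4 is a number 3.7 percentage points higher from compound 2 to compound 4 (within the scatter). Compound 4 is therefore expected to give about 9% in this assay, within a range from 2% to 28%.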

Compound 4, percent of the compound remaining: 3.7%
The estimate for compound 4 lay 5.3 percentage points above the measured number; the range from low to high includes it.
By their numbers in this assay, from the lowest: compounds 4 and 2 (each within the scatter of the next); then compound 3.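

Among the compounds shown here, this is the first direct reading of a change at this position, an aromatic carbon of the five-membered aromatic ring, next to the ring nitrogen and next to the ring sulfur. In this assay, putting amino in place of hydrogen gives a number 1.6 percentage points lower from compound 2 to compound 4 (within the scatter), so the 2-amino-1,3-benzothiazol-7-yl compound cannot be told apart from its 1,3-benzothiazol-7-yl partner. Nothing measured here speaks to why the two compounds read alike.

On these data alone, whether a methylamino group or a carboxylic acid at this same position would also leave the number within the scatter remains open. As far as these compounds go, it is equally open whether amino would have the same outcome in a compound carrying the sulfonyl chain of compound 3, where the number starts from 41% and a fall would have more room to show.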